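The source may report more compounds than this note shows. Statements on the series, on what has been measured and on what is new or still open speak of the compounds shown alone.

Measured so far in an assay on isolated protein for inhibition of Indoleamine 2,3-dioxygenase 1 (Homo sapiens), with a stated time of 60 min, tested at 10 uM; a higher number here means more inhibition at the concentration tested (going by the name of the read-out), a lower number less inhibition:

compound 1 `c1ccc(CCc2ccccc2CSc2nccs2)cc1`, which gives 31%
compound 2 `O=S(=O)(Cc1ccccc1)c1ccccc1CSc1nc2cc(Cl)ccc2[nH]1`, which gives 24%
compound 3 `Clc1ccc2[nH]c(SCc3ccccc3/C=C\c3ccccc3)nc2c1`, which gives 49%

Compound 3 stands highest of the three numbers in this assay. The nearest is compound 1, whose value is lower by a gap beyond the scatter; the furthest is compound 2, whose value is lower by a larger gap, also beyond the scatter. Within the data shown here, compounds 1 and 2 share no single-point step with compound 3 or with each other, so their values can only be read side by side, not as a series. The core of compound 3 recurs in compound 4 `Clc1ccc2[nH]c(SCc3ccccc3/C=C/c3ccccc3)nc2c1`, which has not yet been measured. The change from compound 3 to compound 4 is the two compounds have the same atoms and bonds and differ only in configuration as drawn: 1 of 1 stereo elements differ; a double bond is drawn Z in compound 3 and E in compound 4.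

Among the measured compounds shown here, no measured pair shows what a change in drawn double-bond configuration alone does in this assay, so the direction of the step cannot be taken from the data. The expectation is a step from compound 3 to compound 4 of about a number 7 percentage points lower from compound 3 to compound 4 (within the scatter), small and possibly within the scatter, in either direction. Compound 4 is therefore estimated at 42%, expected to fall between 20% and 65%.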

Compound 4, a percentage reported as inhibition, at one concentration (the size of the read-out at that concentration, not a potency): -6%
Estimate against measurement, compound 4: 48 percentage points above, outside the stated range (below it).
By their numbers in this assay, from the lowest: compound 4; then compounds 2 and 1 (each within the scatter of the next); then compound 3.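

In this assay, the double bond proves to be a position where the drawn configuration matters, with a number 55 percentage points lower from compound 3 to compound 4 (beyond the scatter). For this pair, the Z and E forms cannot be treated as interchangeable, and only the Z form, compound 3, keeps a measurable level of inhibition at the tested concentration. The earlier compounds shown here differed from one another in more than one place and could not isolate any single change, whereas this step can be assigned to the double bond alone: the fact that compounds 3 and 4 differ only in the configuration as drawn.

The compounds shown leave open whether this dependence on configuration holds with a different core, as only one Z and E pair is available and nothing here tests the same change on the core of compound 1. They also leave open whether an amide in place of the double bond, or a carboxylic acid or an amine on the ring at the far end of it, would retain or lose the inhibition seen with compound 3, and how the chloro group on the shared core contributes.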